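Working notes: a larger group on the carbonyl carbon

The compounds below may be only part of what the source reports. "The series", "measured", "known", "first", "only" and "open" are said of these compounds alone.

In a physicochemical assay for solubility, at pH 7.4 (a higher number here means a more soluble compound, a lower number a less soluble compound), compound 2 `CN(C(=O)[C@H]1CN(S(=O)(=O)c2ccccc2)C[C@@H]1NC(=O)c1cc(-c2ccccc2Cl)on1)[C@H]1CCCNC1` gives 113000 nM, the lowest of three numbers. Compound 1 `O=C(N[C@H]1CN(S(=O)(=O)c2ccccc2)C[C@@H]1C(=O)N1C[C@H]2CCNC[C@H]21)c1cc(-c2ccccc2Cl)on1` gives 265000 nM, and compound 3 `CN(C(=O)[C@H]1CN(S(=O)(=O)c2ccccc2)C[C@@H]1N(C)C(=O)c1cc(-c2ccccc2Cl)on1)[C@H]1CCCNC1` gives 553000 nM. Compound 4 `CC(=O)N1CCC[C@H](NC(=O)[C@H]2CN(S(=O)(=O)c3ccccc3)C[C@@H]2NC(=O)c2cc(-c3ccccc3Cl)on2)C1` is unmeasured, and its change is a group of 10 heavy atoms (7 carbon, 2 nitrogen, 1 oxygen; one six-membered non-aromatic ring with 1 hetero atom) in place of a group of 8 heavy atoms (6 carbon, 2 nitrogen; one six-membered non-aromatic ring with 1 hetero atom), on a carbonyl carbon.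

Two measured steps offer guidance. The modest 2.3-fold lower number from compound 1 to compound 2 (0.37 log units; beyond the scatter) exchanges a group on the same carbonyl carbon. The modest 4.9-fold higher number from compound 2 to compound 3 (0.69 log units; beyond the scatter) sits elsewhere, on an amide-type nitrogen, and indicates only the size of movement in this small set. Among the measured compounds shown here, no measured step makes this exact exchange, so the direction is a tentative call. The estimated change is a 1.9-fold lower number from compound 2 to compound 4 (0.27 log units; within the scatter), a modest step to a lower number. Compound 4 is expected at 60000 nM, with an estimated range of 15000 nM to 180000 nM.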

Compound 4, solubility: < 500 nM
Compound 4: a limit, no number; the forecaster's own chance of this, stated with the estimate: 5%; middle value at least 120-fold (2.07 log units) from the limit.
By their numbers in this assay, from the lowest: compound 2; then compound 1; then compound 3. At a limit, below all of these: compound 4.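

In this assay, among the compounds shown here, the group on a carbonyl carbon proved far more sensitive than the earlier compounds suggested, with an at least 220-fold lower number from compound 2 to compound 4 (2.35 log units; beyond the scatter) and an at least 530-fold lower number from compound 1 to compound 4 (2.72 log units; beyond the scatter) as two large steps. As far as these compounds go, both sizes are minimums, so the full size of the change stays unknown. The value of compound 4 is a limit, not a number: the limit of < 500 nM in this assay, at which 1 of the 4 values shown sits.

The exchange swaps a whole group, so the compounds shown do not separate which part of the entering group carries the step. From the compounds shown here alone, how a carboxylic acid on that group would read in this assay also stays open.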